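Moving the carbonyl within the oxopiperazine ring

This account rests on a few compounds, and the source may have more. Where it says the series, first, only, none or still open, it means among the compounds named here.

Compound 1 `O=C(NCCCCc1ccccc1)n1c(=O)oc2cc(C3CCCCC3)ccc21`: 89 nM
Compound 2 `CN1CCN(c2ccc3c(c2)oc(=O)n3C(=O)NCCCCc2ccccc2)C(=O)C1`: 52 nM
Compound 3 `CCC(C)NC(=O)n1c(=O)oc2cc(C3CCN(C)CC3)ccc21`: 2100 nM

In an assay on HEK293 cells for inhibition of acid ceramidase (Homo sapiens), read by fluorescence, with stated times of 10 min and 3 h (a lower number here means a stronger inhibitor, a higher number a weaker inhibitor), compound 2 gives the lowest number of the three, yet its nearest neighbour, compound 1, differs from it by only a 1.7-fold lower number from compound 1 to compound 2 (0.23 log units; within the scatter), and that step is within the scatter, so the two cannot be ordered. Compound 3 sits far from both, but it differs from compound 2 in more than one place, so its value alone says little about any single change.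

Compound 4 `CN1CCN(c2ccc3c(c2)oc(=O)n3C(=O)NCCCCc2ccccc2)CC1=O` is the unmeasured partner of compound 2. The two share every atom and differ only in how the ring is joined to the core: 4-methyl-3-oxopiperazin-1-yl in place of 4-methyl-2-oxopiperazin-1-yl on an aromatic carbon.

Within the data shown here, the one measured step, from compound 1 to compound 2, exchanges a carbon ring for this oxopiperazine and stays within the scatter; no measured step moves the carbonyl inside the ring itself. With so little to go on, the change is expected to leave this assay essentially unmoved, giving a 1.2-fold higher number from compound 2 to compound 4 (0.06 log units; within the scatter) within the scatter in either direction.

Compound 4 is therefore estimated at 60 nM, with a range from 20 nM to 200 nM.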

Compound 4, half-maximal inhibitory concentration in the acid ceramidase assay: 92 nM
Compound 4: the middle estimate sits 1.5-fold (0.19 log units) below what was measured; the measured number falls inside the stated range.
By their numbers in the acid ceramidase assay, from the lowest: compounds 2, 1 and 4 (each within the scatter of the next); then compound 3.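

In the acid ceramidase assay, moving the carbonyl within the ring gives a 1.8-fold higher number from compound 2 to compound 4 (0.25 log units; within the scatter), and replacing cyclohexyl with 4-methyl-3-oxopiperazin-1-yl gives a 1.0-fold higher number from compound 1 to compound 4 (0.01 log units; within the scatter), so compound 1, compound 2 and compound 4 cannot be ordered, and this assay does not tell the two oxopiperazines apart. In a physicochemical assay for solubility, read by HPLC, in phosphate buffer, measured as kinetic solubility, with a stated time of 1 h, at pH 7.4, tested at 250 uM (a higher number here means a more soluble compound, a lower number a less soluble compound), however, the same move of the carbonyl separates the two compounds, with an at least 20-fold lower number from compound 2 to compound 4 (1.30 log units; beyond the scatter), even though the two groups have the same atoms and the same counts of hydrogen-bond donors and acceptors. In the physicochemical assay, compound 2 gives 20000 nM. In the physicochemical assay, compound 4 gives < 1000 nM, which is a limit of the assay and not a number.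

What in the move of the carbonyl lies behind this split between the two assays cannot be told from these values, and the full size of the step in the physicochemical assay remains unknown. As far as these compounds go, it also remains open whether a morpholine or a piperazine bearing a carboxylic acid on the same aromatic carbon would stay level with compound 2 in the acid ceramidase assay and how it would read in the physicochemical assay.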